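The source may report more compounds than this note shows. Statements on the series, on what has been measured and on what is new or still open speak of the compounds shown alone.

In a toxicity assay on THP-1 cells (Homo sapiens) for inhibition (on this read-out lower numbers stand for higher toxicity in this test and higher numbers for lower toxicity in this test), compound 1 (`COc1ccc(-c2cnc(NC(=O)c3ncc[nH]3)n2C)cc1`) gives > 100000 nM as a limit of the assay, not a number. Compound 2 (`COc1ccc(-c2cnc(NC(=O)c3cccc([N+](=O)[O-])c3)n2C)cc1`) gives > 100000 nM as a limit as well. Compound 3 (`COc1ccc(-c2cn(C)c(NC(=O)c3ccc(F)cc3)n2)cc1`) gives > 50000 nM as a limit too. Compound 1 therefore stands without a number, and the three measured compounds cannot be ordered against one another in this assay on what is shown. For the measured compounds named here, no pair among them differs in one place, so there is no measured step to scale from.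

Compound 4 (`CCC(=O)Nc1ncc(-c2ccc(OC)cc2)n1C`) keeps the core of compound 1 and takes ethyl in place of 1H-imidazol-2-yl on a carbonyl carbon, the same difference reading (1H-imidazol-2-yl)carbonyl to propanoyl (ethyl in place of 1H-imidazol-2-yl on a carbonyl carbon).

The expected step of a number no higher from compound 1 to compound 4 (the limit leaves the size open) is none beyond the scatter, with no direction expected. This expectation rests on compound 1 at > 100000 nM as a limit, and on the absence of any number among the three measured compounds, which carry different groups on the carbonyl carbon. The estimate for compound 4 is 100000 nM, with an expected range of 40000 nM to 200000 nM and a report as a limit again the likely outcome.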

Compound 4, half-maximal cytotoxic concentration: > 100000 nM
Compound 4: no number, only a limit (the forecaster's own chance of this, stated with the estimate: 85%); the middle value sits exactly at the limit.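

In this assay compound 4 gives > 100000 nM, a limit of the assay and not a number. No step from compound 1 to compound 4 can be read, as both compounds sit at the same limit: the limit of > 100000 nM in this assay, at which 3 of the 4 values shown sit.

The compounds shown leave open whether any group on the carbonyl carbon gives a readable half-maximal cytotoxic concentration.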